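Acyl variation on the shared core

The compounds below may be only part of what the source reports. "The series", "measured", "known", "first", "only" and "open" are said of these compounds alone.

Measured so far:
compound 1 `CC(C)CCC(=O)N[C@@H](C(=O)N1CCC(c2ccc(Cl)cc2)CC1)C(C)C`: in an assay on THP-1 cells for displacement of a labelled ligand from C-C chemokine receptor type 1 (Homo sapiens) (on this read-out higher numbers stand for weaker inhibition and lower numbers for stronger inhibition), compound 1 gives 26 nM
compound 2 `CC(C)[C@@H](NC(=O)c1ccc(F)cc1)C(=O)N1CCC(c2ccc(Cl)cc2)CC1`: in this assay compound 2 gives 118 nM

Compound 2 stands as the higher of the two numbers in this assay. Among the compounds with values here, the only measured step, a 4.5-fold higher number from compound 1 to compound 2 (0.66 log units; beyond the scatter), came with 4-fluorophenyl in place of isopentyl on the carbonyl carbon and lies beyond the scatter. Compound 3 `Cc1cccc(CCC(=O)N[C@@H](C(=O)N2CCC(c3ccc(Cl)cc3)CC2)C(C)C)c1` is not yet measured; it differs from compound 2 by 2-(3-methylphenyl)ethyl in place of 4-fluorophenyl on a carbonyl carbon. Within the data shown here, the one measured step at this position was modest, and the chain-type group of compound 1 gave the lower number, so a return toward that value is expected. For compound 3 the expected step is a 3.0-fold lower number from compound 2 to compound 3 (0.47 log units; beyond the scatter). Compound 3 is estimated at 40 nM, within 12 nM to 130 nM.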

Compound 3, half-maximal inhibitory concentration: 22 nM
Beside the measured number, compound 3's estimate is 1.8-fold (0.26 log units) above it; low and high end bracket the measured number.
By their numbers in this assay, from the lowest: compounds 3 and 1 (each within the scatter of the next); then compound 2.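

With 2-(3-methylphenyl)ethyl in place of 4-fluorophenyl on the carbonyl carbon, a 5.4-fold lower number from compound 2 to compound 3 (0.73 log units; beyond the scatter) shows that an aromatic ring in this acyl group does not by itself go with the higher number in this assay, as compound 2 and compound 3 both carry one. The change of isopropyl to 3-methylphenyl at the chain end, a 1.2-fold lower number from compound 1 to compound 3 (0.07 log units; within the scatter), leaves the number within the scatter. No evidence here bears on the reason for these steps. Still open, going by these compounds, is how 2-(4-fluorophenyl)ethyl would compare, which would separate the ethyl link from the ring substitution, and whether an amine or a carboxylic acid at the chain end would be accepted.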